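A few compounds are considered here, and "the series" means these few. Any claim that something is new, unique, unknown or untested is made for them only; others in the source may bear on it.

Among the compounds with values here, compound 3 `O=c1c2[nH]c(Cc3ccc(NS(=O)(=O)c4cccc5cccnc45)cc3)nc2n(CC2CC2)c(=O)n1Cc1ccccc1F` gives 450 nM in an assay on isolated protein for inhibition of phosphoenolpyruvate carboxykinase, cytosolic [GTP] (Homo sapiens) (on this read-out lower numbers stand for stronger inhibition and higher numbers for weaker inhibition), the second highest of the three numbers known so far. Its nearest neighbour is compound 1 `Cn1cc(S(=O)(=O)Nc2ccc(Cc3nc4c([nH]3)c(=O)n(Cc3ccccc3F)c(=O)n4CC3CC3)cc2)cn1`, which in this assay gives 390 nM; the gap a 1.2-fold higher number from compound 1 to compound 3 (0.06 log units; within the scatter) lies within the scatter. The furthest is compound 2 `CN(C)CC(=O)Nc1ccc(Cc2nc3c([nH]2)c(=O)n(Cc2ccccc2F)c(=O)n3CC2CC2)cc1`, which in this assay gives 2070 nM.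

Compound 4 `CN(C)S(=O)(=O)Nc1ccc(Cc2nc3c([nH]2)c(=O)n(Cc2ccccc2F)c(=O)n3CC2CC2)cc1` differs from compound 3 in one place: dimethylamino in place of quinolin-8-yl on a sulfonyl sulfur. Within the data shown here, two measured steps bear on this. The step of a 1.2-fold higher number from compound 1 to compound 3 (0.06 log units; within the scatter) shows that swapping one aromatic ring for another on the sulfonyl sulfur changes little. The step of a 5.3-fold higher number from compound 1 to compound 2 (0.72 log units; beyond the scatter), in which the sulfonyl group with its aromatic ring is replaced by a carbonyl carrying a dimethylamino group, shows a modest loss. Among the measured compounds shown here, compound 4 keeps the sulfonyl group but loses the aromatic ring, so the expected outcome sits between these two cases: a loss beyond the scatter, though smaller than the one from compound 1 to compound 2.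

Compound 4 is therefore expected to give 1100 nM in this assay, with a likely range from 450 nM to 2700 nM, an estimated step of a 2.4-fold higher number from compound 3 to compound 4 (0.39 log units; beyond the scatter).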

Compound 4, half-maximal inhibitory concentration: 960 nM
Beside the measured number, compound 4's estimate is 1.1-fold (0.06 log units) above it; low and high end bracket the measured number.
By their numbers in this assay, from the lowest: compounds 1 and 3 (each within the scatter of the next); then compound 4; then compound 2.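

In this assay, the sulfonyl sulfur keeps measurable inhibition with a group that has no ring, but the two aromatic groups, which could not be told apart earlier, both do better than dimethylamino: the replacement of quinolin-8-yl gives a 2.1-fold higher number from compound 3 to compound 4 (0.33 log units; beyond the scatter) and the replacement of 1-methyl-1H-pyrazol-4-yl gives a 2.5-fold higher number from compound 1 to compound 4 (0.39 log units; beyond the scatter) (both modest steps). The other side of compound 4 is new as well, since dimethylsulfamoyl in place of ((dimethylamino)methyl)carbonyl gives a 2.2-fold lower number from compound 2 to compound 4 (0.33 log units; beyond the scatter). This places compound 4 partway along the earlier gap between compound 1 and compound 2. Nothing given here accounts for either step.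

The compounds shown leave open whether the loss follows the missing ring or the nitrogen now bound to the sulfur, which a methyl group, a morpholine or a plain phenyl ring on the sulfonyl sulfur would help to separate. Also open, from the compounds shown here alone, is how much of the step to compound 2 belongs to the carbonyl and how much to its extra carbon, a question that a urea carrying dimethylamino on its carbonyl would address.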